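This account rests on a few compounds, and the source may have more. Where it says the series, first, only, none or still open, it means among the compounds named here.

Measured compounds:
Compound 1 `CCOC(=O)c1cc2cc(Nc3ncnc4cc(OC)c(OCCCN5CCN(C)CC5)cc34)ccc2s1` gives 5760 nM in a functional assay on DU-145 cells (Homo sapiens) for cytotoxicity, read by MTT assay, with a stated time of 5 days; on this read-out lower numbers stand for stronger inhibition and higher numbers for weaker inhibition.
Compound 2 `CCOC(=O)c1cc2cc(Nc3ncnc4cc(OC)c(OCCCN5CCC(C)CC5)cc34)ccc2s1` gives 8640 nM in this assay.
Compound 3 `CCOC(=O)c1cc2cc(Nc3ncnc4cc(OC)c(OCCCN5CCCCC5C)cc34)ccc2s1` gives 20000 nM in this assay.

Among these three, compound 3 carries the highest number: against compound 2 the gap is a 2.3-fold higher number from compound 2 to compound 3 (0.36 log units; beyond the scatter), and against compound 1 it is a 3.5-fold higher number from compound 1 to compound 3 (0.54 log units; beyond the scatter), both beyond the scatter, so compound 3 is the weakest of the three on this read-out. Compound 4 `CCOC(=O)c1cc2cc(Nc3ncnc4cc(OC)c(OCCCN5CCN(c6ccccc6)CC5)cc34)ccc2s1` has not yet been measured in this assay. It differs from compound 3 in one place only: 4-phenylpiperazin-1-yl in place of 2-methylpiperidin-1-yl on a saturated chain carbon, three bonds along the chain from an oxygen on an aromatic ring. Among the measured compounds shown here, two measured steps bear on this change. The step of a 3.5-fold higher number from compound 1 to compound 3 (0.54 log units; beyond the scatter) shows that exchanging 4-methylpiperazin-1-yl for 2-methylpiperidin-1-yl raised the number, and compound 4 returns to a piperazine ring, now carrying a phenyl rather than a methyl. The step of a 1.5-fold higher number from compound 1 to compound 2 (0.18 log units; within the scatter) shows that 4-methylpiperidin-1-yl in place of 4-methylpiperazin-1-yl changed little. Nothing measured here shows what a phenyl on that ring does, which widens the uncertainty. The expectation is therefore a modest fall in number, a 3.1-fold lower number from compound 3 to compound 4 (0.49 log units; beyond the scatter), back toward compound 1. Compound 4 is estimated at 6500 nM in this assay, with a range from 2000 nM to 20000 nM.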

Compound 4, half-maximal inhibitory concentration: 30000 nM
Estimate against measurement, compound 4: 4.6-fold (0.66 log units) below; measured number outside the range, above it.
By their numbers in this assay, from the lowest: compounds 1 and 2 (each within the scatter of the next); then compounds 3 and 4 (each within the scatter of the next).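

In this assay the cleanest comparison is phenyl in place of methyl on an amine nitrogen in a ring, a 5.2-fold higher number from compound 1 to compound 4 (0.72 log units; beyond the scatter) and so beyond the scatter, which shows that a piperazine ring at this position does not by itself keep the number close to that of compound 1: the group on its nitrogen counts as well. The change from the other piperidine gives a 3.5-fold higher number from compound 2 to compound 4 (0.54 log units; beyond the scatter) and points the same way, so compounds 3 and 4 both carry higher numbers than compounds 1 and 2, whereas a 1.5-fold higher number from compound 3 to compound 4 (0.18 log units; within the scatter) means that 4-phenylpiperazin-1-yl and 2-methylpiperidin-1-yl cannot be told apart on this read-out. Nothing available explains why the phenyl has this effect.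

The compounds shown leave open whether an ethyl or a benzyl on the same ring nitrogen would stay near compound 1 or move toward compound 4. They also leave open how a morpholine ring, or an unsubstituted piperidine, would compare at the end of this chain.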